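Sulfone series: methoxy for fluoro and clearance

The source may hold more compounds than are shown below. What is called first, only, known or untested is meant among the compounds shown, and "the series" means these compounds.

Compound 1 `O=S(=O)(c1cc(Cl)cc(Cl)c1)c1cnc2c(F)cccc2c1-c1ccc(F)cc1` and compound 2 `COc1ccc(-c2c(S(=O)(=O)c3cc(Cl)cc(Cl)c3)cnc3c(F)cccc23)cc1` share one core; in an ADME assay on microsomes from liver (Homo sapiens) for metabolic stability, tested at 2.5 uM (on this read-out higher numbers stand for fast clearance and lower numbers for slow clearance), compound 1 gives 1.01 mL/min and compound 2 gives 2.11 mL/min. The change between them, (methoxy in place of fluoro on an aromatic carbon), makes the step of a 2.1-fold higher number from compound 1 to compound 2 (0.32 log units; beyond the scatter). Compound 3 `O=S(=O)(c1ccc(F)c(F)c1)c1cnc2cc(F)ccc2c1-c1cccc(F)c1` rests on a second core; the difference between the two cores is not broken down here. In this assay compound 3 gives 0.6 mL/min. Compound 4 `COc1cccc(-c2c(S(=O)(=O)c3ccc(F)c(F)c3)cnc3cc(F)ccc23)c1` carries the same kind of change on the core of compound 3, (methoxy in place of fluoro on an aromatic carbon); here the place is meta to a large group, whereas in compound 2 it is para to a large group. The number for compound 4 is not yet known. For the measured compounds named here, a step of about the earlier size is expected, a 2.2-fold higher number from compound 3 to compound 4 (0.34 log units; beyond the scatter), because the only measured precedent is a 2.1-fold higher number from compound 1 to compound 2 (0.32 log units; beyond the scatter). Compound 4 is thus estimated at 1.3 mL/min, likely between 0.7 mL/min and 2.5 mL/min.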

Compound 4, intrinsic clearance in a liver preparation (reported as CLH), per the amount of preparation that the assay uses: 1.77 mL/min
Compound 4: middle estimate off by 1.4-fold (0.13 log units), on the low side, within the range that was stated.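

In this assay, the second core repeats the direction seen on the first, with the change from 3-fluorophenyl to 3-methoxyphenyl giving a 3.0-fold higher number from compound 3 to compound 4 (0.47 log units; beyond the scatter). On the two cores shown, the step carries over in direction and does not differ in size: the same change on two cores in this assay, a 2.1-fold higher number (0.32 log units; beyond the scatter) from compound 1 to compound 2 and a 3.0-fold higher number (0.47 log units; beyond the scatter) from compound 3 to compound 4, 1.4-fold (0.15 log units) apart, within the scatter of two such steps. Two pairs do not make a rule for other cores, and the place of the change differs between them, leaving the contributions of core and place unseparated.

Still open, going by these compounds, is whether an ethoxy group, an amine or a nitrile in the same place would follow the methoxy step. Also open, on these data alone, is whether the step holds on a core with other groups on the aromatic ring of the sulfone.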